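This account rests on a few compounds, and the source may have more. Where it says the series, first, only, none or still open, it means among the compounds named here.

Working notes on the benzoxazolyl-phenyl sulfonamide series, read in an assay on isolated protein for inhibition of malate dehydrogenase, mitochondrial (Sus scrofa), with stated times of 45 min and 30 min; a lower number here means a stronger inhibitor, a higher number a weaker inhibitor.

Compound 1 `O=S(=O)(Nc1ccc(-c2nc3ccccc3o2)cc1)c1ccc(Cl)s1` carries a 5-chlorothiophen-2-yl on the sulfonyl sulfur. In this assay compound 1 gives only a limit, > 63000 nM. Compound 2 `O=S(=O)(Nc1ccc(-c2nc3ccccc3o2)cc1)c1cccs1` has hydrogen in place of chloro on an aromatic carbon; in this assay compound 2 likewise gives only a limit, > 63000 nM. Compound 3 `O=S(=O)(Nc1ccc(-c2nc3ccccc3o2)cc1)c1ccccc1O` carries a 2-hydroxyphenyl on the sulfonyl sulfur. In this assay compound 3 too gives only a limit, > 63000 nM. Compound 3 therefore stands at the same limit as every other value in the set, and nothing separates it from compounds 1 and 2 on the numbers shown.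

For the measured compounds named here, none of the measured steps can be sized: a step that the two limits leave unreadable from compound 1 to compound 2, a step that the two limits leave unreadable from compound 1 to compound 3 and a step that the two limits leave unreadable from compound 2 to compound 3 are all unreadable because of the limit of > 63000 nM in this assay, at which 3 of the 3 values shown sit.

Compound 4 `COc1ccc(Cl)cc1S(=O)(=O)Nc1ccc(-c2nc3ccccc3o2)cc1` differs from compound 3 in one place: 5-chloro-2-methoxyphenyl in place of 2-hydroxyphenyl on a sulfonyl sulfur. Going by the values given here, no measured step bears on this change, so no direction and no size can be drawn from the three neighbours; the only expectation rests on the fact that every measured value sits at the limit. Compound 4 is therefore expected to show no step beyond the scatter, a number no higher from compound 3 to compound 4 (the limit leaves the size open), and most probably another limit. Compound 4 is estimated at 63000 nM, in the range 20000 nM to 200000 nM.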

Compound 4, half-maximal inhibitory concentration: > 63000 nM
Compound 4 was reported as a limit; the forecaster's own chance of this, stated with the estimate: 85%; the middle value lies on the limit itself.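

No new step can be read for compound 4 against compound 1, compound 2 or compound 3 in this assay because all four compounds sit at one limit: the limit of > 63000 nM in this assay, at which 4 of the 4 values shown sit.

The compounds shown leave open whether any group on the sulfonyl sulfur gives a readable inhibition in this assay and how these four compounds rank against one another.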